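The compounds below may be only part of what the source reports. "The series", "measured", "known", "first", "only" and "open" are said of these compounds alone.

Compound 1 `O=C(NCc1cc(C(F)(F)F)cc(C(F)(F)F)c1)c1cnc2ccccc2c1-c1ccccc1` carries a single hydrogen on the carbon next to the ring nitrogen of its shared core and an unsubstituted amide nitrogen. In an in vitro assay on UC11MG cells for binding affinity to Substance-P receptor (Homo sapiens), read by radioligand binding (on this read-out lower numbers stand for stronger inhibition and higher numbers for weaker inhibition), compound 1 gives > 1000 nM, which is a limit of the assay rather than a measured number (the limit of > 1000 nM in this assay, at which 1 of the 3 values shown sits). Two measured changes to compound 1 are known. Compound 2 `CN(Cc1cc(C(F)(F)F)cc(C(F)(F)F)c1)C(=O)c1cnc2ccccc2c1-c1ccccc1`, with a methyl on the amide-type nitrogen, gives 0.03 nM in this assay, a step of an at least 33000-fold lower number from compound 1 to compound 2 (4.52 log units; beyond the scatter). Compound 3 `O=C(NCc1cc(C(F)(F)F)cc(C(F)(F)F)c1)c1c(CCl)nc2ccccc2c1-c1ccccc1`, with a chloromethyl on the aromatic carbon, gives 26 nM, a step of an at least 38-fold lower number from compound 1 to compound 3 (1.58 log units; beyond the scatter).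

Compound 4 `O=C(NCc1cc(C(F)(F)F)cc(C(F)(F)F)c1)c1c(CBr)nc2ccccc2c1-c1ccccc1` differs from compound 1 by bromomethyl in place of hydrogen on an aromatic carbon. The step from compound 1 to compound 3 bears directly on this, since bromomethyl and chloromethyl are close relatives at the same place, so a similar large drop in the number is expected. Compound 4 is therefore expected to give 30 nM in this assay, between 8 nM and 120 nM. The expected step is an at least 33-fold lower number from compound 1 to compound 4 (1.52 log units; beyond the scatter).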

Compound 4, half-maximal inhibitory concentration: 0.01 nM
Compound 4: middle estimate off by 3000-fold (3.48 log units), on the high side; measured number outside the range, below it.
By their numbers in this assay, from the lowest: compound 4; then compound 2; then compound 3. At a limit, above all of these: compound 1.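

In this assay, putting bromomethyl on the aromatic carbon next to the ring nitrogen gives an at least 100000-fold lower number from compound 1 to compound 4 (5.00 log units; beyond the scatter). Compound 3 had already shown that a halogen-bearing methyl at this carbon lowers the number, but the step of a 2600-fold lower number from compound 3 to compound 4 (3.41 log units; beyond the scatter) shows that the outcome depends strongly on which halogen is present, even though bromo in place of chloro is the only change. Compound 1 stands at a limit of the assay and not at a measured number, so the step from it gives only a minimum size: the limit of > 1000 nM in this assay, at which 1 of the 4 values shown sits.

The compounds shown do not tell why bromo and chloro differ so much here. A plain methyl, an iodomethyl or an aminomethyl on the same carbon would show whether the large effect is specific to bromomethyl or extends to other groups.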